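The compounds below may be only part of what the source reports. "The series", "measured", "known", "first", "only" and "open" are said of these compounds alone.

Measured so far:
compound 1 `O=S1(=O)C=C(Sc2nnc(-c3cccnc3)o2)c2ccccc21` — 14000 nM
compound 2 `O=S1(=O)C=C(Sc2nnc(C3CCCCC3)o2)c2ccccc21` — 15000 nM

In an ADME assay on HepG2 cells (Homo sapiens) for cytotoxicity, read by fluorescence and resazurin assay, with a stated time of 24 h (on this read-out lower numbers stand for higher toxicity in this test and higher numbers for lower toxicity in this test), compound 1 gives 14000 nM, and compound 2 gives 15000 nM. Going by the values given here, these two values sit within the scatter of each other, so compound 1 cannot be set apart from compound 2 on this read-out; the only step in this small set, a 1.1-fold higher number from compound 1 to compound 2 (0.03 log units; within the scatter), is a null result.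

Compound 3 `O=S1(=O)C=C(Sc2nnc(-c3ccccn3)o2)c2ccccc21` differs from compound 1 by pyridin-2-yl in place of pyridin-3-yl on an aromatic carbon. Among the compounds with values here, no measured step covers this exchange of one pyridinyl for another. Within the data shown here, the one step that touches the same aromatic carbon, a 1.1-fold higher number from compound 1 to compound 2 (0.03 log units; within the scatter), replaced the pyridin-3-yl with a cyclohexyl and produced nothing beyond the scatter, which gives no grounds to expect movement from a smaller rearrangement of the same ring. The expected step is therefore none beyond the scatter, no change at the digits printed from compound 1 to compound 3 (within the scatter).

Compound 3 is estimated at 14000 nM, in a range from 7000 nM to 28000 nM.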

Compound 3, half-maximal cytotoxic concentration: 24000 nM
Estimate against measurement, compound 3: 1.7-fold (0.23 log units) below; measured number inside the range.
By their numbers in this assay, from the lowest: compounds 1, 2 and 3 (each within the scatter of the next).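

In this assay, exchanging pyridin-3-yl for pyridin-2-yl on this aromatic carbon gives a step within the scatter (a 1.7-fold higher number from compound 1 to compound 3 (0.23 log units; within the scatter)), and pyridin-2-yl in place of cyclohexyl does the same (a 1.6-fold higher number from compound 2 to compound 3 (0.20 log units; within the scatter)). The earlier pair compared a pyridinyl ring with cyclohexyl; this result adds that the place of the nitrogen within the pyridinyl ring also produces no step beyond the scatter, so the three groups on this carbon cannot be told apart in this test. Nothing at hand offers an explanation for these numbers.

Going by these compounds, whether a different kind of group on this carbon, such as a carboxylic acid or an amine, would give a step beyond the scatter remains open. So does the question of whether changes elsewhere on the shared core would shift these numbers.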